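Forced swim test: a third methoxy on the coumarin series

A few compounds are considered here, and "the series" means these few. Any claim that something is new, unique, unknown or untested is made for them only; others in the source may bear on it.

Three compounds were examined in a functional assay on the whole organism (strain Swiss albino) with Mus musculus as the target, in the forced swim test, with a stated time of 5 min, at a dose of 0.5 mg/kg by the intraperitoneal route; on this read-out higher numbers stand for more inhibition at the one dose given (going by the name of the read-out) and lower numbers for less inhibition. Compound 1 `COc1ccc(-c2cc3cc(C4C(C#N)=C(N)OC5=C4C(=O)CCC5)cc(C(C)C)c3oc2=O)cc1` gives 69.7% in this assay. Compound 2 `COc1ccc(-c2cc3cc(C4C(C#N)=C(N)OC5=C4C(=O)CCC5)cc(C(C)C)c3oc2=O)cc1OC` is made from compound 1 by one change, (methoxy in place of hydrogen on an aromatic carbon), and in this assay compound 2 gives 57.2%; the step is a number 12.5 percentage points lower from compound 1 to compound 2 (beyond the scatter). Compound 3 `COc1ccc(-c2cc3cc(C4C(C#N)=C(N)OC5=C4C(=O)CC(C)(C)C5)cc(C(C)(C)C)c3oc2=O)cc1OC` rests on a different core; the difference between the two cores is not broken down here. In this assay compound 3 gives 22.5%, the lowest of the three values, and its gaps to compound 2 and to compound 1 both lie beyond the usual scatter.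

Compound 4 `COc1cc(-c2cc3cc(C4C(C#N)=C(N)OC5=C4C(=O)CC(C)(C)C5)cc(C(C)(C)C)c3oc2=O)cc(OC)c1OC` has not been measured. It differs from compound 3 by methoxy in place of hydrogen on an aromatic carbon. Among the measured compounds shown here, this is the same kind of change as the one from compound 1 to compound 2, though the surroundings differ: in compound 4 the entering group is also meta to a methoxy group. Among the compounds shown, that change has been measured only once, from compound 1 to compound 2, where it cost inhibition by a modest amount. If the change behaves the same way on the core of compound 3, the estimate would be a step of a number 10.5 percentage points lower from compound 3 to compound 4 (beyond the scatter), which, starting from the value of compound 3, leaves little room before the read-out reaches its floor. On that basis compound 4 is expected to give about 12% in this assay, with a plausible range from 0% to 32%.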

Compound 4, a percentage reported as inhibition, in the whole organism at one dose (the size of the read-out at that dose, not a potency): 30.1%
Compound 4: middle estimate off by 18.1 percentage points, on the low side; the measured number falls inside the stated range.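

In this assay, the change from 3,4-dimethoxyphenyl to 3,4,5-trimethoxyphenyl gives a number 7.6 percentage points higher from compound 3 to compound 4 (within the scatter), so on this read-out the added methoxy cannot be told apart from the hydrogen it replaces on the core of compound 3. The loss seen when a methoxy entered on the core of compound 1 therefore did not carry over to the core of compound 3, and in this series the result of the change on one core cannot be taken as a guide to its result on the other: the same change on two cores in this assay, a number 12.5 percentage points lower (beyond the scatter) from compound 1 to compound 2 and a number 7.6 percentage points higher (within the scatter) from compound 3 to compound 4, 20.1 percentage points apart, beyond the scatter of two such steps

Among the compounds shown here, this rests on only two pairs and a single dose, and it does not show which difference between the cores matters, or whether the core matters at all, since the entering group in compound 4 also stands meta to a methoxy group and so has different surroundings. The compounds shown leave open how the same third methoxy would read on the core of compound 1, where the step from a 3,4-dimethoxyphenyl group could be compared directly. They also leave open whether a hydroxy group, a chlorine atom or a dimethylamino group in that place on the aromatic ring would follow either step.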